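The source may hold more compounds than are shown below. What is called first, only, known or untested is meant among the compounds shown, and "the series" means these compounds.

Compound 1 `Clc1ccc(CO/N=C/c2c(-c3ccc4ccccc4c3)nc3sccn23)cc1Cl` gives 380 nM in an assay on HepG2 cells for agonist activity at nuclear receptor subfamily 1 group I member 3 (Homo sapiens), read by a luciferase reporter, with a stated time of 23 h; on this read-out lower numbers stand for an effect already at smaller amounts and higher numbers for an effect only at larger amounts of compound. Compound 2 `CCc1nc2sccn2c1/C=N/OCc1ccc(Cl)c(Cl)c1` gives 2600 nM.

Among these two measurements compound 2 stands at the higher number; its nearest neighbour is compound 1, and the only step measured so far is a 6.8-fold higher number from compound 1 to compound 2 (0.84 log units; beyond the scatter). Compound 3 `Clc1ccc(CO/N=C/c2c(-c3ccccc3)nc3sccn23)cc1Cl` departs from compound 2 by phenyl in place of ethyl on an aromatic carbon. This change runs in the opposite sense to the measured step, since it restores an aromatic ring at the position where compound 1 carries naphthalen-2-yl, though phenyl is not the same group. Because the step of a 6.8-fold higher number from compound 1 to compound 2 (0.84 log units; beyond the scatter) was beyond the scatter, compound 3 is expected to fall below compound 2 in this assay, but probably short of compound 1. The expected step is a 3.3-fold lower number from compound 2 to compound 3 (0.51 log units; beyond the scatter). Compound 3 is accordingly estimated at 800 nM, within a range from 300 nM to 2500 nM.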

Compound 3, half-maximal effective concentration: 580 nM
The estimate for compound 3 lay 1.4-fold (0.14 log units) above the measured number; the measured number falls inside the stated range.
By their numbers in this assay, from the lowest: compounds 1 and 3 (each within the scatter of the next); then compound 2.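

In this assay the change at this aromatic carbon, next to the ring nitrogen, gives a 4.5-fold lower number from compound 2 to compound 3 (0.65 log units; beyond the scatter) and so shows that a single phenyl ring is enough to move the number clearly away from that of the ethyl compound. The other new step is a 1.5-fold higher number from compound 1 to compound 3 (0.18 log units; within the scatter) and lies within the scatter, so naphthalen-2-yl and phenyl cannot be told apart at this position, which the earlier step alone could not show. Nothing available explains why these aromatic groups differ from ethyl.

The compounds shown leave open whether an aromatic ring is needed here at all, which a cyclohexyl ring or a longer chain such as hexyl would test. They also leave open how a pyridine ring, or a phenyl ring carrying a methoxy group, would compare with phenyl.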